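Chain Extension and Ring Hydroxy Loss in a Cytotoxicity Series

The source may hold more compounds than are shown below. What is called first, only, known or untested is meant among the compounds shown, and "the series" means these compounds.

All three measured compounds were tested in a functional assay on HEL cells (Homo sapiens) for cytotoxicity (a higher number here means that more compound is tolerated, a lower number that less compound is tolerated), and each value is a limit of the assay.

Compound 1, `CCCCC#Cc1cc2cn([C@@H]3O[C@H](CO)[C@@H](O)[C@H]3O)c(=O)nc2o1`, gives > 144000 nM.
Compound 2, `CCCCCCC#Cc1cc2cn([C@@H]3O[C@H](CO)[C@@H](O)[C@H]3O)c(=O)nc2o1`, gives >= 133000 nM.
Compound 3, `CCCCC#Cc1cc2cn([C@H]3C[C@H](O)[C@@H](CO)O3)c(=O)nc2o1`, gives > 150000 nM.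

Compound 2 differs from compound 1 by ethyl in place of hydrogen on a saturated chain carbon, four bonds along the chain from a triple-bonded carbon. The step that the two limits leave unreadable from compound 1 to compound 2 cannot be sized. Compound 1 stands at the limit of > 144000 nM in this assay, at which 1 of the 3 values shown sits. Compound 2 stands at the limit of >= 133000 nM in this assay, at which 1 of the 3 values shown sits.

The core of compound 3 differs from that of compound 1 by hydrogen in place of hydroxy on a saturated ring carbon. The step that the two limits leave unreadable from compound 1 to compound 3 is likewise not readable. Compound 3 stands at the limit of > 150000 nM in this assay, at which 1 of the 3 values shown sits.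

Compound 4, `CCCCCCC#Cc1cc2cn([C@H]3C[C@H](O)[C@@H](CO)O3)c(=O)nc2o1`, is not yet measured. It differs from compound 3 by ethyl in place of hydrogen on a saturated chain carbon, four bonds along the chain from a triple-bonded carbon, the same change as from compound 1 to compound 2, at the same place. The step of an at least 1.0-fold lower number from compound 3 to compound 4 (0.02 log units; that floor lies within the scatter) is expected to be small. This expectation rests on compound 3 standing at the limit of > 150000 nM in this assay, at which 1 of the 3 values shown sits, and on the earlier step being a step that the two limits leave unreadable from compound 1 to compound 2. For compound 4 the estimate in this assay is 140000 nM, within 70000 nM to 200000 nM, and the assay will most likely again report only a limit.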

Compound 4, minimum cytotoxic concentration: >= 97000 nM
Compound 4: a limit, no number; the forecaster's own chance of this, stated with the estimate: 85%; the middle value is on the limit's open side.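

Compound 4 again gives only a limit in this assay, so its steps from compound 3 and from compound 2 cannot be read. The compounds shown leave open how large either the ethyl-for-hydrogen or the hydrogen-for-hydroxy change is.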